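Working notes on Vero cytotoxicity, compound 3 to compound 4

The source may report more compounds than this note shows. Statements on the series, on what has been measured and on what is new or still open speak of the compounds shown alone.

Measured so far:
compound 1 `CCc1nc2ccccc2n1CCCOc1ccccc1`: > 50 uM (a limit)
compound 2 `CCc1nc2ccccc2n1CCCCOc1ccccc1C(C)C`: 19 uM
compound 3 `CCc1nc2ccccc2n1CCCCOc1cccc(Cl)c1`: 22 uM

In an ADME assay on Vero cells (Chlorocebus sabaeus) for cytotoxicity, read by luminescence, with a stated time of 2 days (on this read-out lower numbers stand for higher toxicity in this test and higher numbers for lower toxicity in this test), compound 1 gives only a limit, > 50 uM, as recorded in the limit of > 50 uM in this assay, at which 1 of the 3 values shown sits. Among the two actual numbers, compound 3 at 22 uM is the higher, but compound 2 at 19 uM lies within the scatter of it, so the two are not distinguished in this assay. The next compound, compound 4 `CCc1nc2ccccc2n1CCCCOc1ccc(Cl)cc1C`, is not yet measured. It carries 4-chloro-2-methylphenyl in place of 3-chlorophenyl on an oxygen on a saturated carbon. Among the compounds with values here, no measured pair shows the effect of such a change. The expected step from compound 3 to compound 4 in this assay, a 1.2-fold lower number from compound 3 to compound 4 (0.09 log units; within the scatter), is small and within the scatter. For compound 4 the expected value in this assay is 18 uM, with a range from 8 uM to 45 uM.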

Compound 4, half-maximal toxic concentration: 20 uM
The estimate for compound 4 lay 1.1-fold (0.05 log units) below the measured number; measured number inside the range.
By their numbers in this assay, from the lowest: compounds 2, 4 and 3 (each within the scatter of the next). At a limit, above all of these: compound 1.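

In this assay, 4-chloro-2-methylphenyl in place of 3-chlorophenyl on an oxygen on a saturated carbon gives a 1.1-fold lower number from compound 3 to compound 4 (0.04 log units; within the scatter). Within the data shown here, this is the first measured pair that differs in one place, and it shows that this change at this position does not separate the two compounds in this read-out. Nothing measured here bears on the reason for this result. Going by these compounds, whether an amine or a carboxylic acid on this aromatic ring would shift the number remains open. No pair shown differs in the chain alone, leaving its contribution open too.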